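The source may report more compounds than this note shows. Statements on the series, on what has been measured and on what is new or still open speak of the compounds shown alone.

Working notes on the series, read in a functional assay on A549 cells (Homo sapiens) for cytotoxicity, read by MTT assay, with a stated time of 72 h; on this read-out lower numbers stand for stronger inhibition and higher numbers for weaker inhibition. Compound 3 `CN(C)Cc1ccc2nc(NC(=O)N/N=C/c3c[nH]c4ccccc34)sc2c1` gives 3300 nM. Compound 1 `CC1CCN(Cc2ccc3nc(NC(=O)N/N=C/c4c[nH]c5ccccc45)sc3c2)CC1` gives 3580 nM, and compound 2 `CCN(CC)Cc1ccc2nc(NC(=O)N/N=C/c3cn(Cc4cccc(Cl)c4)c4ccccc34)sc2c1` gives 2410 nM. Both of these numbers lie within the scatter of compound 3, so it holds no distinct rank among the three.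

Compound 4 `CCN(CC)Cc1ccc2nc(NC(=O)N/N=C/c3c[nH]c4ccccc34)sc2c1` carries a single change relative to compound 3: diethylamino in place of dimethylamino on a saturated chain carbon bound to an aromatic carbon. This is diethylamino in place of dimethylamino on a saturated chain carbon bound to an aromatic carbon. For the measured compounds named here, the only measured step at this place is a 1.1-fold lower number from compound 1 to compound 3 (0.04 log units; within the scatter), with dimethylamino in place of 4-methylpiperidin-1-yl, and it stays within the scatter. Compound 2 already bears diethylamino, but it differs from compound 4 elsewhere on the core as well, so compound 2 offers only a loose reference at 2410 nM.

The expected size of the step is a 1.1-fold lower number from compound 3 to compound 4 (0.03 log units; within the scatter), with no shift beyond the scatter in either direction. The estimated value for compound 4 is 3100 nM, with an expected range of 1600 nM to 6000 nM.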

Compound 4, half-maximal inhibitory concentration: 3300 nM
Compound 4: the middle estimate sits 1.1-fold (0.03 log units) below what was measured, and the stated range covers the measured number.
By their numbers in this assay, from the lowest: compounds 2, 3, 4 and 1 (each within the scatter of the next).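

In this assay, with hydrogen on the aromatic nitrogen, diethylamino does not separate from dimethylamino (no change at the digits printed from compound 3 to compound 4 (within the scatter)) or from 4-methylpiperidin-1-yl (a 1.1-fold lower number from compound 1 to compound 4 (0.04 log units; within the scatter)), so these three amines on a saturated chain carbon bound to an aromatic carbon now read as one level. Compound 2 also changes from a loose reference into a single-place comparison, and hydrogen in place of 3-chlorobenzyl on an aromatic nitrogen stays within the scatter (a 1.4-fold higher number from compound 2 to compound 4 (0.14 log units; within the scatter)).

From the compounds shown here alone, whether a carboxylic acid or a morpholine at this place would depart from this level remains open, as does the reading of 3-chlorobenzyl on the aromatic nitrogen with any amine other than diethylamino. No further data on hand bear on this result.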